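Swapping chlorine for fluorine on a second core

This account rests on a few compounds, and the source may have more. Where it says the series, first, only, none or still open, it means among the compounds named here.

Of the compounds shown here, three have been measured in a functional assay on HCT-116 cells (Homo sapiens) for inhibition, in the presence of a further agent that is not named here; a higher number here means a weaker inhibitor of growth, a lower number a stronger inhibitor of growth. Compound 1, `CCc1nc(N)nc(N)c1-c1ccc2[nH]c(-c3ccc(Cl)cc3)[n+]([O-])c2c1`, gives 9000 nM in this assay. Compound 2, `CCc1nc(N)nc(N)c1-c1ccc2[nH]c(-c3ccc(F)cc3)[n+]([O-])c2c1`, differs from it in one place, (fluoro in place of chloro on an aromatic carbon), and gives 22000 nM, so the change made a 2.4-fold higher number from compound 1 to compound 2 (0.39 log units; beyond the scatter).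

Compound 3, `Nc1ncc(-c2ccc(NCc3ccc(Cl)cc3)c([N+](=O)[O-])c2)cn1`, is built on a different core; the difference between the two cores is not broken down here. In this assay compound 3 gives 5000 nM, a value within the usual scatter of that of compound 1, while compound 2 sits beyond the scatter from it.

Compound 4, `Nc1ncc(-c2ccc(NCc3ccc(F)cc3)c([N+](=O)[O-])c2)cn1`, has not yet been measured. It carries the same change relative to compound 3 that compound 2 carries relative to compound 1: fluoro in place of chloro on an aromatic carbon. Cut one bond further out the change reads 4-chlorobenzyl to 4-fluorobenzyl in this pair, against 4-chlorophenyl to 4-fluorophenyl in the earlier pair, but the place is described in the same words for both.

Within the data shown here, because the same change gave a 2.4-fold higher number from compound 1 to compound 2 (0.39 log units; beyond the scatter), the step from compound 3 to compound 4 in this assay is expected to be of similar size, a 2.4-fold higher number from compound 3 to compound 4 (0.38 log units; beyond the scatter), with the caveat that only one earlier example of this change is at hand and it sits on a different core. Compound 4 is therefore estimated at 12000 nM, most likely between 5000 nM and 30000 nM.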

Compound 4, concentration for 50% growth inhibition: 47000 nM
Estimate against measurement, compound 4: 3.9-fold (0.59 log units) below; the measured number lies above the stated range.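

In this assay, putting fluoro in place of chloro on the aromatic carbon again weakened growth inhibition, with a 9.4-fold higher number from compound 3 to compound 4 (0.97 log units; beyond the scatter). So the direction of the change carried over from one core to the other, while its size did not, and a step measured on one core gave only a rough guide to the step on the other: the same change on two cores in this assay, a 2.4-fold higher number (0.39 log units; beyond the scatter) from compound 1 to compound 2 and a 9.4-fold higher number (0.97 log units; beyond the scatter) from compound 3 to compound 4, 3.8-fold (0.58 log units) apart, beyond the scatter of two such steps. These two pairs show neither why the size differs nor what drives it, since the change sits on a 4-chlorophenyl group in one pair and on a 4-chlorobenzyl group in the other, and the cores differ as well, so the part played by each cannot be separated, and two pairs cannot establish a rule for the whole series.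

The compounds shown leave open how a bromo group, a methoxy group or a plain hydrogen at this same place would compare with chloro and fluoro on either core, and whether the weakening seen with fluoro would extend to such groups. They also leave open whether a third core would give a step close to the smaller one, close to the larger one, or outside both.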